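A few compounds are considered here, and "the series" means these few. Any claim that something is new, unique, unknown or untested is made for them only; others in the source may bear on it.

For the measured compounds named here, in an ADME assay on MRC5 cells (Homo sapiens) for inhibition, with a stated time of 72 h (on this read-out lower numbers stand for an effect already at smaller amounts and higher numbers for an effect only at larger amounts of compound), compound 1 (`CCc1ccccc1C(=O)Nc1c[nH]nc1C(=O)N[C@H]1CC[C@H](OC)CC1`) gives 3400 nM, the only actual number so far. Compound 2 (`COc1cccc(OC)c1C(=O)Nc1c[nH]nc1C(=O)NC1CC1`) reads > 50000 nM, which is a limit of the assay and not a number. Compound 3 (`CO[C@H]1CC[C@H](NC(=O)c2n[nH]cc2NC(=O)c2cc3ccccn3n2)CC1`) has not yet been measured. It differs from compound 1 in one place, on a carbonyl carbon: a group of 9 heavy atoms (7 carbon, 2 nitrogen; one five-membered aromatic ring with 2 hetero atoms, one six-membered aromatic ring with 1 hetero atom) in place of a group of 8 heavy atoms (8 carbon; one six-membered aromatic ring of carbon only), on a carbonyl carbon. The 2-ethylphenyl group leaves, and a group with one five-membered aromatic ring with 2 hetero atoms and one six-membered aromatic ring with 1 hetero atom enters. Going by the values given here, no measured pair shows a change of this kind, so the expectation starts from compound 1 at 3400 nM. A moderate move towards higher numbers in this assay, beyond the usual scatter, is expected: a 3.5-fold higher number from compound 1 to compound 3 (0.55 log units; beyond the scatter). For compound 3 the estimated value is 12000 nM, with an expected range from 3000 nM to 50000 nM.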

Compound 3, half-maximal effective concentration: 1000 nM
The estimate for compound 3 lay 12-fold (1.08 log units) above the measured number, outside the stated range (below it).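

In this assay, for the compounds shown here, replacing the 2-ethylphenyl group on the carbonyl carbon gives a 3.4-fold lower number from compound 1 to compound 3 (0.53 log units; beyond the scatter) and is the first change at this place that can be read. It shows that this place accepts a group with a five-membered and a six-membered aromatic ring, and with hydrogen-bond acceptors that the 2-ethylphenyl group lacks, while the number moves down rather than up. Nothing measured here accounts for the size or direction of this step.

One step cannot separate the contribution of the ring nitrogens from that of the change in ring type. On these data alone, it remains open whether an unsubstituted phenyl or a pyridine ring on the same carbonyl carbon would read closer to compound 1 or to compound 3, and how a morpholine or a carboxylic acid there would read.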